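The source may report more compounds than this note shows. Statements on the series, on what has been measured and on what is new or still open speak of the compounds shown alone.

Measured so far:
compound 1, `CCN(CC)CN1C(=O)/C(=N/NC(=S)Nc2ccccc2)c2cc(Cl)ccc21`: >= 800 nM
compound 2, `CCN(CC)CN1C(=O)/C(=N/NC(=S)Nc2ccc(Cl)cc2)c2ccccc21`: 800 nM
compound 3, `CCN(CC)CN1C(=O)/C(=N/NC(N)=S)c2cc(Cl)ccc21`: 100000 nM

The series is read in an ADME assay on MDCK cells (Canis lupus familiaris) for cytotoxicity; a lower number here means that less compound is tolerated, a higher number that more compound is tolerated. The value of compound 1, >= 800 nM, is a limit of this assay, not a number. Compound 2 gives 800 nM and stands lowest of the two numbers shown; its nearest neighbour is compound 3 at 100000 nM, a gap beyond the scatter. For the measured compounds named here, the only single-point step between measured compounds, a step that the limit leaves unreadable from compound 1 to compound 3, is hydrogen in place of phenyl on an amide-type nitrogen, and its size cannot be read because of the limit of >= 800 nM in this assay, at which 1 of the 3 values shown sits.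

Compound 4, `CCN(CC)CN1C(=O)/C(=N/NC(=S)Nc2ccc(OC)cc2)c2ccccc21`, differs from compound 2 by methoxy in place of chloro on an aromatic carbon. Going by the values given here, no measured step in this assay touches a substituent on that ring, so no step bears directly on this change; the shared core and the thiosemicarbazone side of the molecule are unchanged. With nothing to point in either direction, the step from compound 2 to compound 4 is expected to stay within the scatter, no change at the digits printed from compound 2 to compound 4 (within the scatter). Compound 4 is therefore estimated at 800 nM in this assay, with a range from 400 nM to 1600 nM.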

Compound 4, minimum cytotoxic concentration: 4000 nM
Compound 4: middle estimate off by 5.0-fold (0.70 log units), on the low side; the measured number lies above the stated range.
By their numbers in this assay, from the lowest: compound 2; then compound 4; then compound 3.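

In this assay, the group on this aromatic ring now gives a readable change: methoxy in place of chloro, para to a large group, gives a 5.0-fold higher number from compound 2 to compound 4 (0.70 log units; beyond the scatter). For the compounds shown here, the earlier compounds held no step at this place, so this pair is the first sign that the number responds to the group carried here, with the rest of the molecule unchanged. The pair is still a single comparison, and nothing measured in the series bears on why the number moves with this exchange.

As far as these compounds go, it remains open whether the step would extend to other groups at the same place, such as an amine or a carboxylic acid, and whether the number would then move further in the same direction or turn back towards that of compound 2. The value of compound 1, >= 800 nM, is a limit of this assay and not a number, so the steps that touch compound 1 cannot be read.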